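Nitro in Place of Hydrogen: What Compound 4 Should Show

This account rests on a few compounds, and the source may have more. Where it says the series, first, only, none or still open, it means among the compounds named here.

Of the compounds shown here, three have been measured in an ADME assay on RAW264.7 cells (Mus musculus) for cytotoxicity, read by MTT assay, with a stated time of 72 h, tested at 100 uM; on this read-out higher numbers stand for a stronger effect at the one concentration tested and lower numbers for a weaker effect. Compound 3 `O=C(Cn1c(=O)oc2ccccc21)Nc1ccccc1` carries a simple phenyl amide and gives 39.8%. Compound 2 `O=C(Cn1c(=O)oc2cc([N+](=O)[O-])ccc21)Nc1ccccc1` differs from it by nitro in place of hydrogen on an aromatic carbon and gives 26.4%. That one change produced a number 13.4 percentage points lower from compound 3 to compound 2 (beyond the scatter). Compound 1 `O=C(Cn1c(=O)oc2ccccc21)Nc1nc2ccccc2s1` has a different core; the difference between the cores of compound 1 and compound 3 is not broken down here. In this assay compound 1 gives 59.6%, the highest of the three numbers, and its steps to both others lie beyond the scatter.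

Compound 4 `O=C(Cn1c(=O)oc2ccccc21)Nc1nc2ccc([N+](=O)[O-])cc2s1` has not yet been measured. It differs from compound 1 by nitro in place of hydrogen on an aromatic carbon. The place of the entering group is described in the same words for both pairs, so this is the same change that turned compound 3 into compound 2. Within this small set that change has been seen only once, so the expectation rests on a single observed step and on the position of compound 1 as the starting point.

The step from compound 1 to compound 4 is estimated as a number 13.6 percentage points lower from compound 1 to compound 4 (beyond the scatter), because the matching change earlier gave a number 13.4 percentage points lower from compound 3 to compound 2 (beyond the scatter). Compound 4 is therefore expected to give about 46% in this assay. For compound 4 a range from 34% to 58% is considered likely.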

Compound 4, a percentage reported as inhibition, at one concentration (the size of the read-out at that concentration, not a potency): 19.2%
Compound 4: the middle estimate sits 26.8 percentage points above what was measured, outside the stated range (below it).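

On the core of compound 1, nitro in place of hydrogen on an aromatic carbon gave a number 40.4 percentage points lower from compound 1 to compound 4 (beyond the scatter) in this assay, a large step. Both steps run the same way, but the change did not carry over from one core to the other with the same size: the same change on two cores in this assay, a number 13.4 percentage points lower (beyond the scatter) from compound 3 to compound 2 and a number 40.4 percentage points lower (beyond the scatter) from compound 1 to compound 4, 27 percentage points apart, beyond the scatter of two such steps. So within these two pairs, the direction of the change held while its size depended on the core it was made on, but two pairs cannot give a rule for a further core and offer no explanation for the gap between the steps.

The compounds shown leave open whether another group in the same place, such as an amine or a carboxylic acid, would also lower the number and would again do so by different amounts on the two cores. They also leave open how the compounds would compare across a range of concentrations, since each number here gives the size of the effect at one concentration and is not a potency.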